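Series notes: amine replacements on the shared core

The source may report more compounds than this note shows. Statements on the series, on what has been measured and on what is new or still open speak of the compounds shown alone.

Measured so far:
compound 1 `CC(C)N(C)c1ncnc2c1ncn2Cc1ccccc1` — 17%
compound 2 `c1ccc(Cn2cnc3c(N4CCC4)ncnc32)cc1` — 17%

In a functional assay on the whole organism for inhibition, with Rattus norvegicus as the target, in the maximal electroshock model, at a dose of 25 mg/kg by the intraperitoneal route (a higher number here means more inhibition at the dose given (going by the name of the read-out), a lower number less inhibition), compound 1 gives 17% and compound 2 gives 17%; the step of no change at the digits printed from compound 1 to compound 2 (within the scatter) is flat. Compound 2 therefore stands level with compound 1 on the numbers shown. Compound 3 `CN(C=O)c1ncnc2c1ncn2Cc1ccccc1` is not yet measured; it differs from compound 2 thus: formyl(methyl)amino in place of azetidin-1-yl on an aromatic carbon. For the measured compounds named here, only the step from compound 1 to compound 2 bears on this change, and it showed nothing beyond the scatter, so a step of no change at the digits printed from compound 2 to compound 3 (within the scatter) is expected, none beyond the scatter. Compound 3 is estimated at 17%, within 5% to 35%.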

Compound 3, a percentage reported as inhibition, in the whole organism at one dose (the size of the read-out at that dose, not a potency): 0%
Estimate against measurement, compound 3: 17 percentage points above; measured number below the stated range.
By their numbers in this assay, from the lowest: compound 3; then compounds 1 and 2 (each within the scatter of the next).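

In this assay, this position on the aromatic carbon is no longer flat once a formyl group enters: the change to formyl(methyl)amino gives a number 17 percentage points lower from compound 2 to compound 3 (beyond the scatter) where the two earlier amines showed no separation. Formyl in place of isopropyl on the nitrogen gives a number 17 percentage points lower from compound 1 to compound 3 (beyond the scatter) as well, so the drop appears whether the group leaving carries a ring or not. Nothing on hand explains this drop. Open, going by these compounds, is whether acetyl on the same nitrogen behaves like formyl, and whether a plain dimethylamino group stays with the amines.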